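Sulfonyl-acrylonitrile indole series: removing the aryl methoxy

The source may hold more compounds than are shown below. What is called first, only, known or untested is meant among the compounds shown, and "the series" means these compounds.

Measured so far:
compound 1 `COc1ccc(-c2[nH]c3ccccc3c2/C=C(\C#N)S(=O)(=O)c2ccccc2)cc1` — 10700 nM
compound 2 `COc1ccc(-c2[nH]c3ccc(OC)cc3c2/C=C(\C#N)S(=O)(=O)c2ccccc2)cc1` — 46100 nM

For the measured compounds named here, compound 1 holds the lower of the two numbers in a functional assay on UACC-257 cells (Homo sapiens) for inhibition, read by sulforhodamine B assay, with a stated time of 48 h; a lower number here means a stronger inhibitor of growth, a higher number a weaker inhibitor of growth; the only measured neighbour, compound 2, differs by methoxy in place of hydrogen on an aromatic carbon of the shared core and gives a 4.3-fold higher number from compound 1 to compound 2 (0.63 log units; beyond the scatter).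

Compound 3 `N#C/C(=C\c1c(-c2ccccc2)[nH]c2ccccc12)S(=O)(=O)c1ccccc1` is not yet measured. It differs from compound 1 by hydrogen in place of methoxy on an aromatic carbon, that is, 4-methoxyphenyl to phenyl, the change sitting para to a large group.

Going by the values given here, only one measured step bears on this, and only loosely: adding a methoxy elsewhere on the core cost modestly (a 4.3-fold higher number from compound 1 to compound 2 (0.63 log units; beyond the scatter)). Removing a methoxy at a different position need not mirror that, so the expected step for compound 3 is small, if anything toward a lower number, and likely within the scatter: a 1.4-fold lower number from compound 1 to compound 3 (0.15 log units; within the scatter). Compound 3 is therefore estimated at 7500 nM, between 2500 nM and 22000 nM.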

Compound 3, concentration for 50% growth inhibition: 18200 nM
Beside the measured number, compound 3's estimate is 2.4-fold (0.39 log units) below it; the measured number falls inside the stated range.
By their numbers in this assay, from the lowest: compounds 1 and 3 (each within the scatter of the next); then compound 2.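

In this assay, going from 4-methoxyphenyl to phenyl gives a 1.7-fold higher number from compound 1 to compound 3 (0.23 log units; within the scatter), so the methoxy at this place, para to a large group, can be removed with no change that rises above the scatter. The earlier step, a 4.3-fold higher number from compound 1 to compound 2 (0.63 log units; beyond the scatter), concerned a methoxy added elsewhere on the shared core and went beyond the scatter, so the two places do not respond alike to this one group. No measurement at hand offers an explanation for this result or for that contrast.

On these data alone, what the same place would do with a different group stays open: an amine, a carboxylic acid or a longer chain such as butoxy could each give a different reading. Whether the flat outcome holds beyond hydrogen and methoxy cannot be judged from this single pair.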